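Adding a Chloro Group to a Trifluoromethyl Pyridyl Ether

A few compounds are considered here, and "the series" means these few. Any claim that something is new, unique, unknown or untested is made for them only; others in the source may bear on it.

Measured compounds:
compound 1, `O=C1NC(=O)C(Cc2ccc(Oc3ncc(Cl)cc3Cl)cc2)S1`: 90 nM
compound 2, `O=C1NC(=O)C(Cc2ccc(Oc3ccc(C(F)(F)F)cn3)cc2)S1`: 558 nM
compound 3, `Cc1ccc(C)c(Oc2ccc(CC3SC(=O)NC3=O)cc2)c1`: 238 nM

In a functional assay for agonist activity at Free fatty acid receptor 1 (Homo sapiens), read by FLIPR, in the presence of a further agent that is not named here (on this read-out higher numbers stand for an effect only at larger amounts of compound and lower numbers for an effect already at smaller amounts), compound 2 gives the highest of the three numbers, so it needs the largest amount for a half-maximal effect. Compound 3 stands nearest, with a lower number that is beyond the scatter, and compound 1 stands furthest, with a much lower number.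

Compound 4, `O=C1NC(=O)C(Cc2ccc(Oc3ncc(C(F)(F)F)cc3Cl)cc2)S1`, has not been measured. It differs from compound 2 by one change: chloro in place of hydrogen on an aromatic carbon. Compound 1 bears two chloro groups on the ring where compound 2 bears one trifluoromethyl group and a hydrogen, and compound 1 reaches its effect at a far smaller amount in this assay than compound 2. Going by the values given here, since compound 4 moves the substitution pattern of compound 2 toward that of compound 1, a step toward a lower number is expected, although no directly comparable step has been measured.

The step of a 3.7-fold lower number from compound 2 to compound 4 (0.57 log units; beyond the scatter) is expected to lie beyond the scatter, toward an effect at smaller amounts. Compound 4 is expected to give 150 nM, with a range from 50 nM to 450 nM.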

Compound 4, half-maximal effective concentration: 69 nM
Beside the measured number, compound 4's estimate is 2.2-fold (0.34 log units) above it; the range from low to high includes it.
By their numbers in this assay, from the lowest: compounds 4 and 1 (each within the scatter of the next); then compound 3; then compound 2.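

In this assay, a chloro group on this aromatic carbon, ortho to a large group and two atoms from the ring nitrogen, gives an 8.1-fold lower number from compound 2 to compound 4 (0.91 log units; beyond the scatter) and so shows that a single added atom at this position can shift the number well beyond the scatter. With that chloro group in place, the change at the other ring carbon gives a 1.3-fold lower number from compound 1 to compound 4 (0.12 log units; within the scatter) and stays within the scatter, so trifluoromethyl and chloro cannot be told apart there in this pair. No supporting measurement bears on the reason for these results.

On these data alone, it remains open whether a methoxy group, a nitrile or an amine on the same carbon would give a number like that of chloro. As far as these compounds go, it is also open whether the added chloro group would have a similar effect with a carboxylic acid or a longer chain in place of the trifluoromethyl group.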